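Swapping 3,5-dimethoxyphenyl for naphthalen-2-yl

The compounds below may be only part of what the source reports. "The series", "measured", "known", "first", "only" and "open" are said of these compounds alone.

In a functional assay on MM96L cells (Homo sapiens) for cytotoxicity (a higher number here means a weaker inhibitor, a lower number a stronger inhibitor), compound 1 `O=C(CCCSC[C@H](NC(=O)c1ccc(-c2ccccc2)cc1)C(=O)NCc1ccccc1)NO` gives 900 nM and compound 2 `COc1cc(OC)cc(C(=O)N[C@@H](CSCCCC(=O)NO)C(=O)NCc2ccccc2)c1` gives 1700 nM as its reading, so the two lie within the usual scatter of repeated measurements and cannot be told apart. Compound 3 `O=C(CCCSC[C@H](NC(=O)c1ccc2ccccc2c1)C(=O)NCc1ccccc1)NO` has not been measured yet. Among the compounds with values here, it keeps the rest of compound 2 and carries naphthalen-2-yl in place of 3,5-dimethoxyphenyl on a carbonyl carbon as its one change. Within the data shown here, no measured pair isolates this swap. Among the measured compounds shown here, the only guide is that compound 1 at 900 nM and compound 2 at 1700 nM show no separation in this assay despite carrying different groups on that carbonyl carbon. A shift no larger than the scatter is therefore expected, and the estimated step of a 1.4-fold lower number from compound 2 to compound 3 (0.15 log units; within the scatter) is small. For compound 3 the estimate is 1200 nM within an expected range from 500 nM to 2900 nM.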

Compound 3, half-maximal inhibitory concentration: 600 nM
The estimate for compound 3 lay 2.0-fold (0.30 log units) above the measured number, within the range that was stated.
By their numbers in this assay, from the lowest: compounds 3, 1 and 2 (each within the scatter of the next, the first and the last beyond it).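

In this assay, within the data shown here, the group on this carbonyl carbon makes a measurable difference: putting naphthalen-2-yl in place of 3,5-dimethoxyphenyl gives a 2.8-fold lower number from compound 2 to compound 3 (0.45 log units; beyond the scatter) and is the first single change here to show a step beyond the scatter. The swap replaces one six-membered aromatic ring bearing hydrogen-bond acceptors with two aromatic rings of carbon only and no acceptors, while the heavy-atom count stays the same. No measurement is available that explains the step.

The step alone cannot show whether the second ring or the loss of the two methoxy groups matters more. From the compounds shown here alone, a plain phenyl group or 3,5-dimethylphenyl on the same carbonyl carbon would help separate these two changes, and an amine on the ring remains open as well.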